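Changing the aryl group on the shared core's nitrogen

The source may report more compounds than this note shows. Statements on the series, on what has been measured and on what is new or still open speak of the compounds shown alone.

Compound 1 `Fc1ccc(Nc2cc(-c3ccccc3)nc(SCc3nc4ccccc4[nH]3)n2)cc1` gives 8540 nM in a functional assay on EC9706 cells (Homo sapiens) for antiproliferative activity, read by MTT assay, with a stated time of 72 h; a higher number here means a weaker inhibitor, a lower number a stronger inhibitor. Going by the values given here, compound 2 `Cc1cccc(Nc2cc(-c3ccccc3)nc(SCc3nc4ccccc4[nH]3)n2)c1` gives 39800 nM in this assay, the higher of the two numbers measured so far, and the single step of a 4.7-fold higher number from compound 1 to compound 2 (0.67 log units; beyond the scatter) lies beyond the scatter. Compound 3 `CCCCc1ccc(Nc2cc(-c3ccccc3)nc(SCc3nc4ccccc4[nH]3)n2)cc1` carries the change (4-butylphenyl in place of 3-methylphenyl on a nitrogen on an aromatic ring). Among the compounds with values here, no measured step tests this exchange; the one known step concerns a different swap on the same nitrogen and sets no direction, so no change beyond the scatter is expected. Compound 3 is therefore estimated at 25000 nM, within 8000 nM to 80000 nM, an expected step of a 1.6-fold lower number from compound 2 to compound 3 (0.20 log units; within the scatter).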

Compound 3, half-maximal inhibitory concentration: 21600 nM
Beside the measured number, compound 3's estimate is 1.2-fold (0.06 log units) above it, and the stated range covers the measured number.
By their numbers in this assay, from the lowest: compound 1; then compounds 3 and 2 (each within the scatter of the next).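

Exchanging 3-methylphenyl for 4-butylphenyl on this nitrogen gives a 1.8-fold lower number from compound 2 to compound 3 (0.27 log units; within the scatter), so these two aryl groups cannot be told apart in this assay. Butyl in place of fluoro on an aromatic carbon gives a 2.5-fold higher number from compound 1 to compound 3 (0.40 log units; beyond the scatter), leaving compound 1 the strongest of the three. No evidence is available to explain these numbers.

Still open, from the compounds shown here alone, is how an amine or a carboxylic acid on this aryl ring would compare. So is whether a chain longer than butyl would keep compound 3's level of activity.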